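From cyclohexyl to cycloheptyl: a small ring change

The source may report more compounds than this note shows. Statements on the series, on what has been measured and on what is new or still open speak of the compounds shown alone.

Compound 1 `O=c1[nH]c(OCC2CCCCC2)nc2cnccc12`: 4.5
Compound 2 `O=c1[nH]c(Oc2cccc(O)c2)nc2cnccc12`: 0.3
Compound 3 `O=c1[nH]c(Oc2cnn(C3CCCCC3)c2)nc2cnccc12`: 2.2

All three compounds have been measured in a physicochemical assay for lipophilicity, at pH 7.4; on this read-out lower numbers stand for lower lipophilicity and higher numbers for higher lipophilicity. Compound 3 stands second highest of the three. Its value lies beyond the usual scatter from both of the others, above compound 2 and under compound 1. No two of these compounds differ in only one place, so none of the measured pairs shows directly what a single swap does.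

The next compound, compound 4 `O=c1[nH]c(Oc2cnn(C3CCCCCC3)c2)nc2cnccc12`, keeps all of compound 3 except one group: cycloheptyl in place of cyclohexyl on an aromatic nitrogen. This is a small change beside the wide differences among the measured compounds, whose values run from compound 2 at 0.3 to compound 1 at 4.5. Starting from compound 3 at 2.2, a modest rise in this assay is expected, not a jump of that size. The expected change is a number 0.40 log units higher from compound 3 to compound 4 (beyond the scatter), a step only a little beyond the usual scatter. For compound 4 the estimated value is 2.6, with an expected range from 2.2 to 3.1.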

Compound 4, distribution coefficient: 2.9
Estimate against measurement, compound 4: 0.30 log units below, and the stated range covers the measured number.
By their numbers in this assay, from the lowest: compound 2; then compound 3; then compound 4; then compound 1.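

In this assay, within the data shown here, replacing cyclohexyl with cycloheptyl on an aromatic nitrogen gives a number 0.70 log units higher from compound 3 to compound 4 (beyond the scatter), and this is the first comparison here in which only one part of the molecule changes. It shows that this position on the five-membered aromatic ring with 2 nitrogen is sensitive to a small change: going from a six-membered to a seven-membered carbon ring moves the value beyond the usual scatter, even though neither group has hydrogen-bond donors, hydrogen-bond acceptors or a net charge. Nothing measured here bears on the reason for this step.

The compounds shown leave open whether the value would keep moving the same way with cyclooctyl, or whether cyclopentyl or an open chain such as hexyl on the same nitrogen would fit the same pattern. They also leave open how far a cyclohexyl ring carrying an amine or a carboxylic acid would shift the value at this position, since a single step between two rings of carbon only cannot show how other kinds of group would behave there.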